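The source may hold more compounds than are shown below. What is called first, only, known or untested is meant among the compounds shown, and "the series" means these compounds.

Among the measured compounds shown here, compound 1 `Cc1n[nH]c(C(=O)O)c1Cc1cccc(-c2ccc(C#N)cc2)c1` is the stronger of the two measured members of this small set. In an assay on isolated protein for inhibition of 2-Hydroxyacid oxidase 2 (Rattus norvegicus) (on this read-out higher numbers stand for weaker inhibition and lower numbers for stronger inhibition), compound 1 gives 300 nM, the lowest of the two numbers in hand. For the measured compounds named here, its only measured neighbour is compound 2 `Cc1n[nH]c(C(=O)O)c1Cc1cccc(C(N)=O)c1`, which in this assay gives 900 nM; the single measured step, a 3.0-fold higher number from compound 1 to compound 2 (0.48 log units; beyond the scatter), shows that exchanging the whole outer ring for a carbamoyl group weakens inhibition modestly. Compound 3 `Cc1n[nH]c(C(=O)O)c1Cc1cccc(-c2ccc(C(F)(F)F)cc2)c1` keeps the outer ring of compound 1 and alters only the group on it: trifluoromethyl in place of cyano on an aromatic carbon. The change sits on an aromatic carbon of a six-membered aromatic ring of carbon only, para to a large group. Going by the values given here, no measured step bears directly on this exchange; the step from compound 1 to compound 2 concerns the presence of the outer ring as a whole rather than the group carried on it, so it offers little guidance here. With the ring retained, the step in this assay is expected to stay within the scatter, a 1.3-fold higher number from compound 1 to compound 3 (0.12 log units; within the scatter). Compound 3 is therefore expected to give 400 nM in this assay, with a range from 150 nM to 1200 nM.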

Compound 3, half-maximal inhibitory concentration: 400 nM
For compound 3 middle estimate and measured number coincide at the digits printed; measured number inside the range.
By their numbers in this assay, from the lowest: compounds 1 and 3 (each within the scatter of the next); then compound 2.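

In this assay, the exchange of cyano for trifluoromethyl on an aromatic carbon, para to a large group, reads as a 1.3-fold higher number from compound 1 to compound 3 (0.12 log units; within the scatter), so compound 1 and compound 3 cannot be told apart at this position. The earlier step, a 3.0-fold higher number from compound 1 to compound 2 (0.48 log units; beyond the scatter), spoke only of replacing the outer ring as a whole, whereas this one shows that with the ring kept, the group on it can be exchanged without a change beyond the scatter, even though cyano counts as a hydrogen-bond acceptor and trifluoromethyl does not. Nothing available accounts for this result in terms of any measured property of the two groups.

Whether this position would accept just any group remains open, since both groups shown here leave the number where it was, and an amine, a carboxylic acid or a longer chain on the same carbon might behave quite differently. Also open is whether the outer ring needs a group there at all, as the compounds shown do not include one with plain hydrogen on that carbon.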